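The source may report more compounds than this note shows. Statements on the series, on what has been measured and on what is new or still open speak of the compounds shown alone.

In a functional assay on MDA-MB-231 cells (Homo sapiens) for antiproliferative activity, read by sulforhodamine B assay, with a stated time of 48 h (on this read-out higher numbers stand for weaker inhibition of growth and lower numbers for stronger inhibition of growth), compound 1 (`ClC1=C(c2nnc(Nc3ccccc3)s2)CCCc2ccccc21`) gives 947 nM and compound 2 (`Cc1cc2c(cc1C)C(Cl)=C(c1nnc(-c3ccccc3)o1)CCC2`) gives 2760 nM as the higher of the two numbers, a gap beyond the scatter. These two compounds differ in more than one place, so their gap does not isolate any single change. Compound 3 (`Cc1cc2c(cc1C)C(Cl)=C(c1nnc(-c3ccc(F)cc3)o1)CCC2`) is compound 2 with one change, phenyl to 4-fluorophenyl (fluoro in place of hydrogen on an aromatic carbon). Going by the values given here, the series holds no measured example of fluoro in place of hydrogen on an aromatic carbon, so the expectation is weakly founded. The expected step of a 1.4-fold lower number from compound 2 to compound 3 (0.14 log units; within the scatter) is small, leans towards stronger inhibition of growth and is not expected to go beyond the scatter. In this assay the estimated value for compound 3 is 2000 nM with an expected range from 800 nM to 5000 nM around it.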

Compound 3, concentration for 50% growth inhibition: 1400 nM
For compound 3 the middle estimate is 1.4-fold (0.15 log units) above the measured one, and the stated range covers the measured number.
By their numbers in this assay, from the lowest: compounds 1, 3 and 2 (each within the scatter of the next, the first and the last beyond it).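

In this assay, going by these compounds alone, the first example of fluoro in place of hydrogen on an aromatic carbon gives a 2.0-fold lower number from compound 2 to compound 3 (0.29 log units; within the scatter). The 4-fluorophenyl group is therefore accommodated on this six-membered aromatic ring, para to a large group, without a step beyond the scatter. This single pair sets no direction for the change. No measurement on hand accounts for the step.

On these data alone, whether an amine, a methoxy group or a carboxylic acid at this same place would produce a step beyond the scatter remains open, as does the outcome of fluoro elsewhere on the ring. The gaps between compound 1 and the other two compounds cannot be read as the effect of any single change, since compound 1 differs from each in more than one place.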